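The source may hold more compounds than are shown below. What is called first, only, known or untested is meant among the compounds shown, and "the series" means these compounds.

In a functional assay on HL-60 cells (Homo sapiens) for cytotoxicity, read by WST assay, with a stated time of 48 h (a lower number here means a stronger inhibitor, a higher number a weaker inhibitor), compound 3 `CCCCC[C@H](C(C)C)C(c1ccc(O)c(OC)c1)c1ccc(O)c(OC)c1` gives 9600 nM, the lower of the two numbers in the series, and compound 1 `COC[C@H](C)[C@H](C)C(c1ccc(O)c(OC)c1)c1ccc(O)c(OC)c1` gives 82000 nM. Compound 2 `COc1cc(C(c2ccc(O)c(OC)c2)[C@H](C)[C@@H](C)CO)ccc1O` gives > 100000 nM, which is a limit and not a number.

Compound 4 `COc1cc(C(c2ccc(O)c(OC)c2)[C@H](CO)C(C)C)ccc1O` differs from compound 3 by hydroxy in place of butyl on a saturated chain carbon, three bonds along the chain from two aromatic carbons. Read as pentyl to hydroxymethyl, the change runs against two measured steps: an 8.5-fold lower number from compound 1 to compound 3 (0.93 log units; beyond the scatter) and an at least 10-fold lower number from compound 2 to compound 3 (1.01 log units; beyond the scatter). Compound 4 shares the hydroxymethyl with compound 2, so a modest to large rise is expected in this assay. The expected step is an 8.3-fold higher number from compound 3 to compound 4 (0.92 log units; beyond the scatter). For compound 4 the estimated value is 80000 nM, with an expected range of 30000 nM to 200000 nM.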

Compound 4, half-maximal inhibitory concentration: > 100000 nM
Compound 4 gave a limit, no number; the forecaster's own chance of this, stated with the estimate: 50%; middle value at least 1.2-fold (0.09 log units) away from the limit.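

With the isopropyl kept in place, hydroxy in place of butyl on this saturated chain carbon, three bonds along the chain from two aromatic carbons, gives an at least 10-fold higher number from compound 3 to compound 4 (1.01 log units; beyond the scatter). Against the 2-(methoxymethyl)-1-methylpropyl of compound 1, the 1-(hydroxymethyl)-2-methylpropyl gives an at least 1.2-fold higher number from compound 1 to compound 4 (0.08 log units; that floor lies within the scatter), a floor that does not separate the two. The step between compound 2 and compound 4 cannot be read, as both values are limits: the limit of > 100000 nM in this assay, at which 2 of the 4 values shown sit.

From the compounds shown here alone, whether the rise follows the hydroxy or the loss of the butyl stays open, as the two change together. A propyl chain or an amine at this carbon would separate them.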